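The compounds below may be only part of what the source reports. "The series", "measured", "known", "first", "only" and "open" are said of these compounds alone.

Compound 1 `CC(O)(CSc1cccc(S(F)(F)(F)(F)F)c1)C(=O)Nc1ccc(S(F)(F)(F)(F)F)cc1` gives 25000 nM in a functional assay on LNCaP cells (Homo sapiens) for antiproliferative activity, read by propidium iodide staining, with a stated time of 96 h; on this read-out lower numbers stand for stronger inhibition and higher numbers for weaker inhibition.
Compound 2 `CC(O)(CSc1cccc(C(F)(F)F)c1)C(=O)Nc1ccc(S(F)(F)(F)(F)F)cc1` gives 18300 nM in this assay.
Compound 3 `CC(O)(COc1ccc(S(F)(F)(F)(F)F)cc1)C(=O)Nc1cccc(S(F)(F)(F)(F)F)c1` gives 8000 nM in this assay.

Compound 1 and compound 2 differ by one change, (a group of 4 heavy atoms (1 carbon, 3 fluorine; no ring) in place of a group of 6 heavy atoms (5 fluorine, 1 sulfur; no ring), on an aromatic carbon), and this change produced a 1.4-fold lower number from compound 1 to compound 2 (0.14 log units; within the scatter). Compound 4 `CC(O)(COc1ccc(C(F)(F)F)cc1)C(=O)Nc1cccc(S(F)(F)(F)(F)F)c1` has not yet been measured; it differs from compound 3 by a group of 4 heavy atoms (1 carbon, 3 fluorine; no ring) in place of a group of 6 heavy atoms (5 fluorine, 1 sulfur; no ring), on an aromatic carbon. The core of compound 3 differs from that of compound 1, but the difference between the two cores is not broken down here. For the measured compounds named here, the change leading to compound 4 is of the same kind as the one leading to compound 2, though in compound 2 the entering group sits meta to a large group and in compound 4 para to a large group. Because the earlier step of a 1.4-fold lower number from compound 1 to compound 2 (0.14 log units; within the scatter) was small, the expected step of a 1.3-fold lower number from compound 3 to compound 4 (0.12 log units; within the scatter) is estimated to be similarly modest. Compound 4 is therefore expected to give about 6000 nM in this assay, likely between 3000 nM and 14000 nM.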

Compound 4, half-maximal inhibitory concentration: 9600 nM
Estimate against measurement, compound 4: 1.6-fold (0.20 log units) below; low and high end bracket the measured number.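

The new step, on the core of compound 3, is a 1.2-fold higher number from compound 3 to compound 4 (0.08 log units; within the scatter) in this assay. Set beside the earlier step, trifluoromethyl in place of the group of five fluorine atoms and one sulfur gives no detectable difference between the two cores: the same change on two cores in this assay, a 1.4-fold lower number (0.14 log units; within the scatter) from compound 1 to compound 2 and a 1.2-fold higher number (0.08 log units; within the scatter) from compound 3 to compound 4, 1.6-fold (0.21 log units) apart, within the scatter of two such steps. For the compounds shown here, this shows that the exchange left the number within the scatter on both cores, but it rests on only two pairs and does not show that the same would hold on any other core.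

From the compounds shown here alone, what a nitrile or an amine would do in the same place remains open. So does whether the exchange would behave alike on the other aromatic ring of these compounds.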